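Swapping a side chain on a cytotoxic compound

The source may hold more compounds than are shown below. What is called first, only, known or untested is meant among the compounds shown, and "the series" means these compounds.

Compound 1 `O=C(/C=C/c1ccc(CN2C(=O)/C(=C3\Nc4ccccc4\C3=N/O)c3cc(Cl)ccc32)cc1)NO`: 7 nM
Compound 2 `Cc1ccc2c(c1)/C(=C1/Nc3ccccc3/C1=N\O)C(=O)N2Cc1ccc(/C=C/C(=O)NO)cc1`: 10 nM

Among the measured compounds shown here, in a functional assay on NCI-H23 cells (Homo sapiens) for cytotoxicity, read by colorimetric assay (a higher number here means a weaker inhibitor, a lower number a stronger inhibitor), compound 1 stands level with compound 2, its only comparison so far, since the data show a 1.4-fold higher number from compound 1 to compound 2 (0.15 log units; within the scatter). Compound 3 `O=C(NO)c1ccc(CN2C(=O)/C(=C3\Nc4ccccc4\C3=N/O)c3cc(Cl)ccc32)cc1` has not yet been measured and differs from compound 1 at one place: hydroxycarbamoyl in place of 2-(hydroxycarbamoyl)ethenyl on an aromatic carbon. Hydroxycarbamoyl takes the place of 2-(hydroxycarbamoyl)ethenyl on an aromatic carbon. For the measured compounds named here, the one measured step, methyl in place of chloro, is a different change, so no measurement speaks directly to this one. Any expectation is therefore loose. With compound 1 already at 7 nM, a rise in the number seems more likely than a fall, though none is shown. The expected step is a 5.7-fold higher number from compound 1 to compound 3 (0.76 log units; beyond the scatter). For compound 3 the estimated value is 40 nM, with a range of 10 nM to 200 nM.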

Compound 3, half-maximal inhibitory concentration: 50 nM
Beside the measured number, compound 3's estimate is 1.3-fold (0.10 log units) below it; low and high end bracket the measured number.
By their numbers in this assay, from the lowest: compounds 1 and 2 (each within the scatter of the next); then compound 3.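

In this assay, the side chain on the aromatic carbon para to a large group clearly affects the result: replacing 2-(hydroxycarbamoyl)ethenyl with the shorter hydroxycarbamoyl gives a 7.1-fold higher number from compound 1 to compound 3 (0.85 log units; beyond the scatter). Among the compounds shown here, this is the first step to lie beyond the scatter, since methyl in place of chloro did not, yet compound 3 still gives 50 nM, so the ethenyl link is not needed for activity in the nanomolar range. Nothing available explains this loss of potency.

As far as these compounds go, only two side chains can be compared at this position, so it remains open whether a saturated 2-(hydroxycarbamoyl)ethyl chain or a longer chain would match compound 1. A carboxylic acid in place of the hydroxycarbamoyl end also remains an open question.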